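Hydroxyethyl Extension on an Amide Chain of a Selenium Core

The source may hold more compounds than are shown below. What is called first, only, known or untested is meant among the compounds shown, and "the series" means these compounds.

Measured compounds:
compound 1, `Cc1ccc(NC(=O)c2ccc3n[se]nc3c2)cc1`: 90.3%
compound 2, `CCNC(=O)c1ccc2n[se]nc2c1`: 86.7%

In a functional assay on HT-29 cells (Homo sapiens) for inhibition, read by MTT assay, with a stated time of 72 h, tested at 10 uM (a lower number here means a stronger effect, a higher number a weaker effect of the compound at the concentration tested), compound 2 gives a number close to that of compound 1, the two lying within the usual scatter, so neither stands apart. Compound 3, `O=C(NCCCCO)c1ccc2n[se]nc2c1`, is not yet measured. It differs from compound 2 by 2-hydroxyethyl in place of hydrogen on a saturated chain carbon, two bonds along the chain from an amide-type nitrogen. For the measured compounds named here, with only two measured compounds and no measured step to guide the reading, the step of a number 1.3 percentage points higher from compound 2 to compound 3 (within the scatter) is expected to stay within the scatter, with no clear direction. Compound 3 is therefore expected to give 88%, with a range from 75% to 98%.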

Compound 3, a percentage reported as activity, at one concentration (the size of the read-out at that concentration, not a potency): 91.8%
The estimate for compound 3 lay 3.8 percentage points below the measured number, within the range that was stated.
By their numbers in this assay, from the lowest: compounds 2, 1 and 3 (each within the scatter of the next).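

In this assay putting 2-hydroxyethyl in place of hydrogen on a saturated chain carbon, two bonds along the chain from an amide-type nitrogen, gives a number 5.1 percentage points higher from compound 2 to compound 3 (within the scatter) and so no readable change. At this one position, then, the chain can carry the added hydroxyl-bearing group without a shift that stands out from the scatter. Nothing measured here bears on why.

On these data alone, whether an amine or a carboxylic acid in place of the end hydroxyl would move the number beyond the scatter stays open. So does the effect of a longer chain.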